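The source may report more compounds than this note shows. Statements on the series, on what has been measured and on what is new or still open speak of the compounds shown alone.

Three compounds of this series have been measured in a functional assay on HCT-116 cells (Homo sapiens) for cytotoxicity, read by MTT assay, with a stated time of 48 h; a lower number here means a stronger inhibitor, a higher number a weaker inhibitor:

Compound 1 `Cc1nc2c3ccccc3ccc2c2nc3c(ccc4ccccc43)c(-c3cccnc3)c12`: 34200 nM
Compound 2 `Cc1nc2c3ccccc3ccc2c2nc3c(ccc4ccccc43)c(-c3cccc4ccccc34)c12`: 20800 nM
Compound 3 `Cc1nc2c3ccccc3ccc2c2nc3c(ccc4ccccc43)c(-c3ccccc3S)c12`: 1420 nM

Compound 2 holds the second highest of the three numbers. Its nearest neighbour is compound 1, and the step of a 1.6-fold lower number from compound 1 to compound 2 (0.22 log units; within the scatter) lies within the scatter, so the two cannot be ordered. Its furthest neighbour is compound 3, reached by the step of a 15-fold lower number from compound 2 to compound 3 (1.17 log units; beyond the scatter); compound 3 is the strongest inhibitor of the three, as the step of a 24-fold lower number from compound 1 to compound 3 (1.38 log units; beyond the scatter) confirms.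

Compound 4 `Cc1ccc(-c2c3ccc4ccccc4c3nc3c2c(C)nc2c4ccccc4ccc32)cc1` has not yet been measured. It differs from compound 2 in one place: 4-methylphenyl in place of naphthalen-1-yl on an aromatic carbon. Two of the measured steps bear on this change. The step from compound 1 to compound 2 also exchanged one aryl group for another on the same carbon and stayed within the scatter. The two large steps both lead to compound 3, which carries the 2-sulfanylphenyl group. Compound 4 does not carry that group. Compound 4 is therefore expected to land close to compound 2, at 20000 nM with a range of 8000 nM to 50000 nM, the expected step being a 1.0-fold lower number from compound 2 to compound 4 (0.02 log units; within the scatter), not beyond the scatter.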

Compound 4, half-maximal inhibitory concentration: 67000 nM
The estimate for compound 4 lay 3.4-fold (0.53 log units) below the measured number; measured number outside the range, above it.
By their numbers in this assay, from the lowest: compound 3; then compounds 2, 1 and 4 (each within the scatter of the next, the first and the last beyond it).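

In this assay, this position does not treat all carbon-only aryl groups alike: a 3.2-fold higher number from compound 2 to compound 4 (0.51 log units; beyond the scatter) is a modest step, although neither naphthalen-1-yl nor 4-methylphenyl has a hydrogen-bond donor or acceptor or a net charge. Against pyridin-3-yl, the new group can't be told apart, with a 2.0-fold higher number from compound 1 to compound 4 (0.29 log units; within the scatter) staying within the scatter, while a 47-fold higher number from compound 3 to compound 4 (1.67 log units; beyond the scatter) is the largest step seen so far at this position and leaves compound 3, with its 2-sulfanylphenyl group, as the strongest inhibitor of the four. No measurement at hand accounts for these differences.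

The compounds shown leave open whether the sulfanyl group itself sets compound 3 apart, or whether a phenyl ring carrying a hydroxyl or an amine in its place would give a similar number. Going by these compounds, the effect of moving the sulfanyl group elsewhere on that ring also remains unknown.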